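Swapping Cyclohexyl for Dichlorophenyl on the Thioether Arm

The source may report more compounds than this note shows. Statements on the series, on what has been measured and on what is new or still open speak of the compounds shown alone.

Compound 1 `Cc1cc(N2CC[C@@H](C)[C@@H](N(C)c3ncnc4[nH]ccc34)C2)n2ncnc2n1`: 4350 nM
Compound 2 `Cc1cc(N2CC[C@@H](C)[C@@H](N(C)c3ncnc4[nH]ccc34)C2)n2nc(SCC3CCCCC3)nc2n1`: 9170 nM
Compound 3 `CCc1cc(N2CC[C@@H](C)[C@@H](N(C)c3ncnc4[nH]ccc34)C2)n2ncnc2n1`: 80200 nM

In a functional assay on MGC-803 cells (Homo sapiens) for inhibition, read by MTT assay, with a stated time of 72 h (on this read-out higher numbers stand for weaker inhibition and lower numbers for stronger inhibition), compound 2 gives 9170 nM, the second highest of the three numbers. Its nearest neighbour is compound 1, separated by a 2.1-fold higher number from compound 1 to compound 2 (0.32 log units; beyond the scatter); the furthest is compound 3, whose jump from compound 1 was an 18-fold higher number from compound 1 to compound 3 (1.27 log units; beyond the scatter).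

Compound 4 `Cc1cc(N2CC[C@@H](C)[C@@H](N(C)c3ncnc4[nH]ccc34)C2)n2nc(SCc3cc(Cl)ccc3Cl)nc2n1` differs from compound 2 by 2,5-dichlorophenyl in place of cyclohexyl on a saturated chain carbon bound to a sulfur. Within the data shown here, only a 2.1-fold higher number from compound 1 to compound 2 (0.32 log units; beyond the scatter) concerns the same sulfur-bearing arm, and that step was modest; no measured step exchanges the group on the saturated chain carbon bound to the sulfur, so there is no direct guide. The expected step is therefore small, a 1.1-fold lower number from compound 2 to compound 4 (0.06 log units; within the scatter), with no clear direction. Compound 4 is estimated at 8000 nM, within 2500 nM to 25000 nM.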

Compound 4, half-maximal inhibitory concentration: 9850 nM
For compound 4 the middle estimate is 1.2-fold (0.09 log units) below the measured one; low and high end bracket the measured number.
By their numbers in this assay, from the lowest: compound 1; then compounds 2 and 4 (each within the scatter of the next); then compound 3.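

In this assay, exchanging cyclohexyl for 2,5-dichlorophenyl on the saturated chain carbon bound to a sulfur gives a 1.1-fold higher number from compound 2 to compound 4 (0.03 log units; within the scatter), so a saturated carbon ring and a chlorinated aromatic ring read alike at this place. Against hydrogen on the aromatic carbon, the (2,5-dichlorobenzyl)sulfanyl arm gives a 2.3-fold higher number from compound 1 to compound 4 (0.35 log units; beyond the scatter), so both sulfur arms shown read weaker than hydrogen there. Nothing measured here explains this result. Open, going by these compounds, is how a benzyl group without chlorine, or an amine at the end of the sulfur arm, would read, and whether either arm could give a lower number than compound 1.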